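Hydroxy on the ethoxy chain of compound 3

This account rests on a few compounds, and the source may have more. Where it says the series, first, only, none or still open, it means among the compounds named here.

In a physicochemical assay for solubility (a lower number here means a less soluble compound, a higher number a more soluble compound), compound 1 `CCOc1ccc2c(c1)C(c1cn[nH]c1)=CN(C)C(=O)[C@@H]2C` gives >= 115 ug/mL, which is a limit. Compound 2 `CCOc1ccc2c(c1)C(c1c[nH]cn1)=CN(C)C(=O)[C@@H]2C` gives >= 131 ug/mL, again a limit. Compound 3 `CCOc1ccc2c(c1)C(c1c[nH]c(C)n1)=CN(C)C(=O)[C@@H]2C` gives >= 135 ug/mL, also a limit, so it has no exact number and no readable rank among the three.

Compound 4 `Cc1nc(C2=CN(C)C(=O)[C@H](C)c3ccc(OCCO)cc32)c[nH]1` keeps the 2-methyl-1H-imidazol-4-yl group of compound 3 and changes the other end of the molecule: hydroxy in place of hydrogen on a saturated chain carbon, two bonds along the chain from an oxygen on an aromatic ring. This is hydroxy in place of hydrogen on a saturated chain carbon, two bonds along the chain from an oxygen on an aromatic ring, turning ethoxy into 2-hydroxyethoxy.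

Among the compounds with values here, none of the measured steps touches the ethoxy group, so they bear on this change only as background. They are a step that the two limits leave unreadable from compound 1 to compound 2, a step that the two limits leave unreadable from compound 1 to compound 3 and a step that the two limits leave unreadable from compound 2 to compound 3. No size can be carried over from them, and no direction can be drawn from them. The only anchor is the limit of compound 3, >= 135 ug/mL.

The expected change is therefore none beyond the scatter, and another limit is the likeliest report. The expected step is a step that the limit leaves unreadable from compound 3 to compound 4. In this assay, the estimate for compound 4 is 140 ug/mL, with an expected range of 95 ug/mL to 200 ug/mL.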

Compound 4, solubility: >= 185 ug/mL
Compound 4: no number, only a limit; the forecaster's own chance of this, stated with the estimate: 80%; middle value at least 1.3-fold (0.12 log units) from the limit.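

In this assay compound 4 gives >= 185 ug/mL, which is a limit. Compound 3 gives >= 135 ug/mL, also a limit, so no step can be read from compound 3 to compound 4. Going by these compounds, whether 2-hydroxyethoxy in place of ethoxy shifts the read-out in this assay, and in which direction or by how much, stays open.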